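The source may report more compounds than this note shows. Statements on the series, on what has been measured and on what is new or still open speak of the compounds shown alone.

Compound 2 `CC(=O)n1cc(/C=C(/C(=O)O)c2ccccc2)c2cc(OCc3ccccc3)ccc21` is one of three compounds already tested in a functional assay on M14 cells (Homo sapiens) for cytotoxicity, read by MTT assay, with a stated time of 72 h; a lower number here means a stronger inhibitor, a higher number a weaker inhibitor. In this assay compound 2 gives > 100000 nM, which is a limit of the assay rather than a number. Compound 1 `COc1cccc(/C(=C\c2cn(C(C)=O)c3ccc(OCc4ccccc4)cc23)C(=O)O)c1` gives > 100000 nM, again a limit. Going by the values given here, compound 3 `COc1cc(/C(=C\c2cn(C(C)=O)c3ccc(OCc4ccccc4)cc23)C(=O)O)cc(OC)c1OC` gives 57100 nM, the only value that is a number. Across the three results, the limit of > 100000 nM in this assay, at which 2 of the 3 values shown sit, sets the scale. The step of an at least 1.7-fold lower number from compound 2 to compound 3 (0.24 log units; that floor lies within the scatter) and the step of an at least 1.7-fold lower number from compound 1 to compound 3 (0.24 log units; that floor lies within the scatter) are therefore floors only, and the step that the two limits leave unreadable from compound 1 to compound 2 cannot be read at all. Compound 4 `CC(=O)n1cc(/C=C(/C(=O)O)c2ccc(OCc3ccccc3)cc2)c2cc(OCc3ccccc3)ccc21` differs from compound 2 by benzyloxy in place of hydrogen on an aromatic carbon. Among the compounds with values here, no measured step covers this particular change, and the measured steps that exist are small or unreadable. Compound 4 is thus expected to stay close to the limit, with a step of a number no higher from compound 2 to compound 4 (the limit leaves the size open) estimated to lie within the scatter. The value expected for compound 4 is 100000 nM, within a range from 30000 nM to 300000 nM.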

Compound 4, half-maximal inhibitory concentration: 58200 nM
For compound 4 the middle estimate is 1.7-fold (0.24 log units) above the measured one; the measured number falls inside the stated range.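

The earlier compounds shown here carried only hydrogen or methoxy groups on this ring. Compound 4 shows that benzyloxy, with its 8 heavy atoms and a further six-membered aromatic ring, can sit para to a large group and still give a readable number in this assay, with an at least 1.7-fold lower number from compound 2 to compound 4 (0.23 log units; that floor lies within the scatter). That step is only a floor, and its true size stays unknown because compound 2 stands at a limit of the assay: the limit of > 100000 nM in this assay, at which 2 of the 4 values shown sit.

On these data alone, whether this change truly alters the reading therefore remains open, since the floor does not clear the usual scatter. The compounds shown also leave open what a different group at this same position, such as an amine, a hydroxyl or a longer alkoxy chain, would do to the number.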